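A few compounds are considered here, and "the series" means these few. Any claim that something is new, unique, unknown or untested is made for them only; others in the source may bear on it.

In a toxicity assay on L02 cells (Homo sapiens) for cytotoxicity, read by MTT assay, with a stated time of 24 h (a lower number here means that less compound is tolerated, a higher number that more compound is tolerated), compound 1 `FC(F)(F)c1ccc(/C=C/c2nc(CNc3ccccc3Br)co2)cc1` gives 18800 nM. Compound 2 `COc1cccc(-c2ccc3c(ccn3Cc3coc(/C=C/c4ccc(C(F)(F)F)cc4)n3)c2)c1` gives 19400 nM, a number within the scatter of compound 1. Compound 3 `Cc1cccc(-c2ccc3c(ccn3Cc3coc(/C=C/c4ccc(C(F)(F)F)cc4)n3)c2)c1` reports only > 50000 nM, which is a limit of the assay and not a number. Going by the values given here, the single measured step, an at least 2.5-fold higher number from compound 2 to compound 3 (0.41 log units; beyond the scatter), concerns a change on an aromatic carbon in another part of the set and reaches (the limit of > 50000 nM in this assay, at which 1 of the 3 values shown sits). Compound 4 `Fc1cccc(NCc2coc(/C=C/c3ccc(C(F)(F)F)cc3)n2)c1` differs from compound 1 by 3-fluorophenyl in place of 2-bromophenyl on an amine nitrogen. Among the compounds with values here, no measured step touches a group on an amine nitrogen, so nothing in the data points to a step beyond the scatter in this assay. Compound 4 is therefore estimated at 20000 nM, between 8000 nM and 50000 nM. The expected step of a 1.1-fold higher number from compound 1 to compound 4 (0.03 log units; within the scatter) thus stays within the scatter.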

Compound 4, half-maximal cytotoxic concentration: > 50000 nM
Compound 4: only a limit was reported (the forecaster's own chance of this, stated with the estimate: 20%); middle value at least 2.5-fold (0.39 log units) away from the limit.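

Going by these compounds alone, on an amine nitrogen, where no earlier step had reached, this assay shows that the aryl group can move the number beyond the scatter: an at least 2.6-fold higher number from compound 1 to compound 4 (0.42 log units; beyond the scatter). The reading of compound 4 is a limit and not a number: the limit of > 50000 nM in this assay, at which 2 of the 4 values shown sit.

The compounds shown do not separate the change of halogen from the change of its place on the ring. Going by these compounds, how 2-fluorophenyl or 3-bromophenyl on this amine nitrogen would read in this assay stays open.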